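The compounds below may be only part of what the source reports. "The series", "measured", "known", "first", "only" and "open" are said of these compounds alone.

Measured compounds:
Compound 1 `CCOC(=O)C1=Cc2ccccc2OC1(OCc1cc(-c2ccc3ccccc3c2)no1)C(F)(F)F`: in a functional assay on HeLa cells (Homo sapiens) for inhibition, read by MTT assay, with a stated time of 24 h (on this read-out lower numbers stand for stronger inhibition and higher numbers for weaker inhibition), compound 1 reaches only the assay limit, > 150000 nM.
Compound 2 `CCCCCCCCn1cc(COC2(C(F)(F)F)Oc3ccccc3C=C2C(=O)OCC)nn1`: in this assay compound 2 likewise reaches only the assay limit, > 150000 nM.

Compound 2 cannot be placed in any order on the numbers shown: its value in this assay is a limit and not a number, and the one other value given, for compound 1, is also a limit, so the two are indistinguishable here. The whole of the evidence is the limit of > 150000 nM in this assay, at which 2 of the 2 values shown sit. For the measured compounds named here, no step between measured compounds is available, so nothing in the data indicates which kind of change moves this series at all.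

Compound 3 `CCOC(=O)C1=Cc2ccccc2OC1(OCc1cn(CC(=O)Nc2ccc(OC)cc2)nn1)C(F)(F)F` differs from compound 2 in one place: (4-methoxyphenyl)carbamoyl in place of heptyl on a saturated chain carbon bound to an aromatic nitrogen. With both measured compounds sitting at the limit, there is no basis to expect this change to bring compound 3 into the measurable range; the expected step in this assay is none beyond the scatter, most probably another limit. The estimate for compound 3 in this assay is 200000 nM, with a range from 60000 nM to 600000 nM. The expected step is a step that the limit leaves unreadable from compound 2 to compound 3.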

Compound 3, half-maximal inhibitory concentration: 31900 nM
For compound 3 the middle estimate is 6.3-fold (0.80 log units) above the measured one, and the stated range ends above it.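

In this assay, (4-methoxyphenyl)carbamoyl in place of heptyl on a saturated chain carbon bound to an aromatic nitrogen gives an at least 4.7-fold lower number from compound 2 to compound 3 (0.67 log units; beyond the scatter), which shows that a change at this position can bring the series into the measurable range. Compound 3 gives 31900 nM, a number and not a limit, and so provides the series with its only measured reference point so far. The step has a floor and no upper end, so its full size cannot be read, as compound 2 stands only at a limit: the limit of > 150000 nM in this assay, at which 2 of the 3 values shown sit.

The change replaces the chain with a carbonyl, an amide hydrogen, an aromatic ring and a methoxy group all at once, so the compounds shown do not tell which of these parts carries the step. From the compounds shown here alone, it remains open whether a plain phenylcarbamoyl without the methoxy group, a ring-free primary amide or a carboxylic acid at this place would keep the read-out within the measurable range, and whether a shorter alkyl chain alone would already leave the limit.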